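A Pyrazole Sulfonamide Replaces a Fluorophenyl Sulfonamide

The source may hold more compounds than are shown below. What is called first, only, known or untested is meant among the compounds shown, and "the series" means these compounds.

Of the compounds shown here, three sharing one core have been measured in an ADME assay (liver) for metabolic stability, with Liver microsome (Homo sapiens) as the target, read by LC-MS, using microsomes and NADPH, with a stated time of 5 min, at 37 degrees C; a lower number here means slower removal, a higher number faster removal of the compound. Compound 1, `CCn1c(C(C)NS(=O)(=O)c2ccc(Cl)cc2)nc2ncccc21`, gives 15 mL.min-1.g-1. Compound 2, `CCn1c([C@@H](C)NS(=O)(=O)c2ccc(F)cc2)nc2ccc(C(F)(F)F)cc21`, gives 26 mL.min-1.g-1, the higher of the two numbers, though its gap to compound 1 lies within the usual scatter, so the two cannot be ordered. Compound 3, `CCn1c([C@@H](C)NS(=O)(=O)c2ccc(NC(C)=O)c(C)c2)nc2ccc(C(F)(F)F)cc21`, reaches only a limit of the assay at > 100 mL.min-1.g-1. That limit, (the limit of > 100 mL.min-1.g-1 in this assay, at which 1 of the 3 values shown sits), shows how far this series can move, but no single-point comparison between measured compounds exists here.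

The step now in view runs from compound 2 to compound 4, `CCCn1ncc(S(=O)(=O)N[C@H](C)c2nc3ccc(C(F)(F)F)cc3n2CC)c1C`. The change is 5-methyl-1-propyl-1H-pyrazol-4-yl in place of 4-fluorophenyl on a sulfonyl sulfur. Within the data shown here, no measured pair shows what this kind of swap does in this assay, so the expectation rests only on the spread of the three values above. A moderate rise in clearance for compound 4 is expected, of about a 1.7-fold higher number from compound 2 to compound 4 (0.24 log units; within the scatter), though the step could fall within the scatter. Compound 4 is therefore estimated at 45 mL.min-1.g-1, with a likely range from 18 mL.min-1.g-1 to 110 mL.min-1.g-1.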

Compound 4, intrinsic clearance in microsomes: > 100 mL.min-1.g-1
Compound 4 gave a limit, no number; the forecaster's own chance of this, stated with the estimate: 15%; middle value at least 2.2-fold (0.34 log units) away from the limit.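

Among these compounds, this is the first measured change at this position on the sulfonyl sulfur: in this assay, putting 5-methyl-1-propyl-1H-pyrazol-4-yl in place of 4-fluorophenyl gives an at least 3.8-fold higher number from compound 2 to compound 4 (0.58 log units; beyond the scatter) and so clearly speeds removal. Among the compounds shown here, the step lies beyond the usual scatter, which the earlier compounds could not show for any single change. From the compounds shown here alone, its full size stays unknown, since compound 4 gives a limit of the assay and no exact number: the limit of > 100 mL.min-1.g-1 in this assay, at which 2 of the 4 values shown sit.

The five-membered ring, its methyl group and the propyl chain all enter together, and these compounds cannot separate their shares in the rise. Going by these compounds, how the series would read with a shorter ethyl group in place of the propyl chain, or with a hydroxyl group on that chain, remains open.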